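The compounds below may be only part of what the source reports. "The series", "measured", "known", "first", "only" and "open" are said of these compounds alone.

The measured compounds in a functional assay on CCRF-CEM cells (Homo sapiens) for antiproliferative activity, read by MTT assay, with a stated time of 48 h, tested at 50 uM; a higher number here means a weaker effect of the compound at the concentration tested, a lower number a stronger effect:
compound 1 `OC(CCn1nc2c(Br)c(Br)c(Br)c(Br)c2n1)c1cccc(Br)c1` gives 0%
compound 2 `COc1cccc(C(O)CCn2nc3c(Br)c(Br)c(Br)c(Br)c3n2)c1` gives 2%
compound 3 `C[C@@H](O)CCn1nc2c(Br)c(Br)c(Br)c(Br)c2n1` gives 23%

Compound 2 stands second highest of these three numbers. Its nearest neighbour is compound 1, whose number lies within the scatter of it; its furthest is compound 3, whose number lies beyond the scatter. Compound 4 `OC(CCn1nc2c(Br)c(Br)c(Br)c(Br)c2n1)c1ccccc1` has not yet been measured. It differs from compound 2 in one place: hydrogen in place of methoxy on an aromatic carbon. The shared core is untouched; only the 3-methoxyphenyl becomes phenyl.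

For the measured compounds named here, one measured step bears on this change, because it alters the same aromatic carbon: a number 2 percentage points higher from compound 1 to compound 2 (within the scatter). Swapping one group for another there left the number essentially unchanged. Going by the values given here, with only that step to go on, no step beyond the scatter is expected in this assay when the methoxy is removed. Compound 4 is therefore estimated at 3%, with a range from 0% to 15%. This estimate means an expected step of a number 1 percentage points higher from compound 2 to compound 4 (within the scatter), within the scatter.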

Compound 4, a percentage reported as activity, at one concentration (the size of the read-out at that concentration, not a potency): 0%
Compound 4: middle estimate off by 3 percentage points, on the high side, and the stated range covers the measured number.
By their numbers in this assay, from the lowest: compounds 1, 4 and 2 (each within the scatter of the next); then compound 3.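

In this assay, removing the methoxy gives a number 2 percentage points lower from compound 2 to compound 4 (within the scatter), and putting hydrogen in place of the bromo gives no change at the digits printed from compound 1 to compound 4 (within the scatter). The earlier step compared only two substituents on this aromatic carbon, whereas the plain phenyl now shows that neither the methoxy nor the bromo is needed for the effect seen at this single concentration. Nothing measured here explains why the three compounds read so alike.

Still open, going by these compounds, is whether this carbon tolerates any group, since an amine or a carboxylic acid there could give a different reading. A reading at one concentration also cannot show whether compound 1, compound 2 and compound 4 would differ in the strength of their effect at lower concentrations.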